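A few compounds are considered here, and "the series" means these few. Any claim that something is new, unique, unknown or untested is made for them only; others in the source may bear on it.

Of the compounds shown here, two built on the same core have been measured in a functional assay on K562 cells (Homo sapiens) for inhibition, read by trypan blue exclusion, with a stated time of 72 h; a higher number here means a weaker inhibitor, a lower number a stronger inhibitor. Compound 1 `Cn1c(=O)c(S(=O)(=O)c2ccc(C(=O)O)cc2)cc2cnc(Nc3ccc4[nH]ccc4c3)nc21` carries a 4-carboxyphenyl group on its sulfonyl sulfur, and in this assay compound 1 gives 5000 nM. Compound 2 `Cn1c(=O)c(S(=O)(=O)c2ccc(F)cc2)cc2cnc(Nc3ccc4cc[nH]c4c3)nc21` is the other measured compound, and in this assay compound 2 gives 10000 nM. Of the two numbers, that of compound 1 is the smaller, but the gap to compound 2 lies within the scatter of repeated measurements, so the two cannot be told apart. Among the compounds with values here, no pair of measured compounds differs in a single place, so no measured step is available to lean on.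

Compound 3 `Cn1c(=O)c(S(=O)(=O)c2ccc([N+](=O)[O-])cc2F)cc2cnc(Nc3ccc4[nH]ccc4c3)nc21` has not yet been measured. It differs from compound 1 in one place: 2-fluoro-4-nitrophenyl in place of 4-carboxyphenyl on a sulfonyl sulfur. Within the data shown here, with only two measured numbers, both close together, there is little to suggest that this change will move the result far in either direction. A small step is therefore expected, a 1.3-fold lower number from compound 1 to compound 3 (0.10 log units; within the scatter), no further than the usual scatter. Compound 3 is expected to give about 4000 nM, within a range from 1000 nM to 15000 nM.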

Compound 3, half-maximal inhibitory concentration: 200 nM
For compound 3 the middle estimate is 20-fold (1.30 log units) above the measured one, and the stated range ends above it.
By their numbers in this assay, from the lowest: compound 3; then compounds 1 and 2 (each within the scatter of the next).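

The group on the sulfonyl sulfur turns out to matter a great deal in this assay: placing 2-fluoro-4-nitrophenyl there instead of 4-carboxyphenyl gives a 25-fold lower number from compound 1 to compound 3 (1.40 log units; beyond the scatter). The earlier compounds shown here could not show this, since compound 1 and compound 2 differ in more than one place and their numbers lie within the scatter of each other, so neither offered a clean reading of this position. This single swap removes the carboxylic acid and brings in a nitro group and a fluorine together, so the step belongs to the whole exchange of groups, and nothing measured here accounts for its size.

The compounds shown leave open how much of the step goes with each new feature, which a phenyl ring carrying the nitro group alone, or the fluorine alone, would help to separate. They also leave open whether the nitro group itself is needed, or whether a nitrile, an amine or a methyl ester on the ring would give a number closer to that of compound 3 or to that of compound 1.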